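The source may report more compounds than this note shows. Statements on the series, on what has been measured and on what is new or still open speak of the compounds shown alone.

In an ADME assay on microsomes from liver (Homo sapiens) for metabolic stability, read by LC-MS, using NADPH, with stated times of 5 min and 30 min, tested at 1 uM (a lower number here means slower removal, a higher number faster removal of the compound), compound 1 `O=C1c2ccccc2CN1c1cnc(NCc2c(F)ccc3c2CCO3)n2cnnc12` gives 13 mL.min-1.g-1. Compound 2 `C[C@@H]1CC(=O)N(c2cnc(NCc3c(F)ccc4c3CCO4)n3cnnc23)C1` gives < 3 mL.min-1.g-1, which is a limit of the assay and not a number. Compound 2 therefore stands at the limit of < 3 mL.min-1.g-1 in this assay, at which 1 of the 2 values shown sits, the low end of what this assay reports here.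

Compound 3 `COCCC(=O)Nc1cnc(NCc2c(F)ccc3c2CCO3)n2cnnc12` keeps the shared core and changes the group on the same aromatic carbon: ((2-methoxyethyl)carbonyl)amino in place of 4-methyl-2-oxopyrrolidin-1-yl on an aromatic carbon. In words, ((2-methoxyethyl)carbonyl)amino replaces 4-methyl-2-oxopyrrolidin-1-yl, and the entering group has no ring.

Within the data shown here, only one measured step bears on this change. It is an at least 4.3-fold lower number from compound 1 to compound 2 (0.63 log units; beyond the scatter), which lies beyond the scatter and shows that the group on this carbon can move the number. That step involved a different pair of groups, so it is a rough guide to size only. With compound 2 known only as a limit, any measurable change would have to be upward.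

The expected change is an at least 2.0-fold higher number from compound 2 to compound 3 (0.30 log units; that floor lies within the scatter), a modest move towards faster removal. For compound 3 the estimated value is 6 mL.min-1.g-1, with an expected range from 3 mL.min-1.g-1 to 15 mL.min-1.g-1.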

Compound 3, intrinsic clearance in microsomes: < 3 mL.min-1.g-1
Compound 3 ended at the assay's limit; the forecaster's own chance of this, stated with the estimate: 30%; at least 2.0-fold (0.30 log units) between middle value and limit.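

With ((2-methoxyethyl)carbonyl)amino on this aromatic carbon, this assay shows an at least 4.3-fold lower number from compound 1 to compound 3 (0.63 log units; beyond the scatter), so the low reading seen with 4-methyl-2-oxopyrrolidin-1-yl does not depend on a ring in the group or on its defined stereocentre. The entering group has 1 hydrogen-bond donor and 2 hydrogen-bond acceptors, where the group it replaces has 0 and 1, yet compound 3 still sits at a limit of the assay and not at a number: the limit of < 3 mL.min-1.g-1 in this assay, at which 2 of the 3 values shown sit. The step between compound 2 and compound 3 cannot be read, and the two groups cannot be placed in order.

The compounds shown do not tell how much the group on this carbon can change before a measurable number returns, since only compound 1 gives one, and it carries a six-membered aromatic ring of carbon only in its group. On these data alone, whether a simple amine, a carboxylic acid or a longer chain on this carbon would stay at the limit or give a number, and how large that number would be, remains open.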